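Methyl in Place of Methoxy on an Aromatic Carbon

The source may report more compounds than this note shows. Statements on the series, on what has been measured and on what is new or still open speak of the compounds shown alone.

In a functional assay on SK-OV-3 cells (Homo sapiens) for inhibition, read by CCK-8 assay, with a stated time of 70 h (a higher number here means a weaker inhibitor, a lower number a stronger inhibitor), compound 1 `COc1ccc(COc2ccc(OCCOCCNC3CCCC3)cc2)cc1` gives 15700 nM and compound 2 `c1ccc(COc2ccc(COc3ccc(OCCOCCNC4CCCCC4)cc3)cc2)cc1` gives 8080 nM there, so these two values lie within the usual scatter of each other. Compound 3 `Cc1ccc(COc2ccc(OCCOCCNC3CCCC3)cc2)cc1` has not yet been measured. It differs from compound 1 by methyl in place of methoxy on an aromatic carbon, para to a large group methyl in place of methoxy on an aromatic carbon and nothing else. Going by the values given here, no measured pair shows what this swap does. The estimate is a 1.2-fold lower number from compound 1 to compound 3 (0.08 log units; within the scatter) and so no change beyond the scatter is expected. In this assay compound 3 is estimated at 13000 nM with a range from 6500 nM to 26000 nM as the expected span.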

Compound 3, half-maximal inhibitory concentration: 17200 nM
Estimate against measurement, compound 3: 1.3-fold (0.12 log units) below; the measured number falls inside the stated range.
By their numbers in this assay, from the lowest: compounds 2, 1 and 3 (each within the scatter of the next, the first and the last beyond it).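

Putting methyl in place of methoxy, para to a large group, gives a 1.1-fold higher number from compound 1 to compound 3 (0.04 log units; within the scatter) in this assay. Compound 3 lacks the hydrogen-bond acceptor counted for methoxy, yet it cannot be told apart from compound 1 in this assay, so this swap at this position gives no measurable difference. Nothing measured here offers an explanation for this result. Still open, on these data alone, is whether an amine or a carboxylic acid at this position would give a number beyond the scatter. A longer chain, such as propyl, is equally untested here.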